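The source may report more compounds than this note shows. Statements on the series, on what has been measured and on what is new or still open speak of the compounds shown alone.

Measured so far in an in vivo functional assay on the whole organism (MDA-MB-435 cells, Homo sapiens) for antiproliferative activity; on this read-out lower numbers stand for stronger inhibition and higher numbers for weaker inhibition:
- compound 1 `CO[C@@H](C(=O)NC1CC[C@@H](OC(=O)c2ccccc2)CNC1=O)[C@H](O)[C@@H](O)[C@H](O)/C=C/C(C)(C)C` gives 370 nM
- compound 2 `CO[C@@H](C(=O)NC1CC[C@@H](OC(=O)C2CCCCCC2)CNC1=O)[C@H](O)[C@@H](O)[C@H](O)/C=C/C(C)(C)C` gives 20 nM

Among the compounds with values here, of these two, compound 2 holds the lower number in this assay, and compound 1 is its only neighbour. The open question is compound 3 `CO[C@@H](C(=O)NC1CC[C@@H](OC(=O)C2CCCC2)CNC1=O)[C@H](O)[C@@H](O)[C@H](O)/C=C/C(C)(C)C`, which shares the core of compound 2 and differs in one group: cyclopentyl in place of cycloheptyl on a carbonyl carbon.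

Within the data shown here, one measured step bears on this place: a 19-fold lower number from compound 1 to compound 2 (1.27 log units; beyond the scatter), with cycloheptyl in place of phenyl on a carbonyl carbon. That step is large and shows that the read-out responds to the group carried here. Among the measured compounds shown here, it is only indirect evidence, as it swaps phenyl for a saturated ring, and no measured pair compares two saturated rings of different size. Compound 3 keeps a non-aromatic carbon ring, as compound 2 does (20 nM), so a change far smaller than the measured step is expected, with a modest rise the likeliest direction. The expected step is a 2.0-fold higher number from compound 2 to compound 3 (0.30 log units; within the scatter). For compound 3 the estimated value is 40 nM, with an expected range from 12 nM to 150 nM.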

Compound 3, half-maximal inhibitory concentration: 130 nM
For compound 3 the middle estimate is 3.3-fold (0.51 log units) below the measured one; measured number inside the range.
By their numbers in this assay, from the lowest: compound 2; then compound 3; then compound 1.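

In this assay, the size of a saturated carbon ring on this carbonyl carbon matters in its own right: a 6.5-fold higher number from compound 2 to compound 3 (0.81 log units; beyond the scatter), a step beyond the scatter that the phenyl-to-cycloheptyl comparison could not reveal. Replacing phenyl with a non-aromatic ring does not by itself give the full gain, since cyclopentyl yields only a 2.8-fold lower number from compound 1 to compound 3 (0.45 log units; beyond the scatter), a smaller step than a 19-fold lower number from compound 1 to compound 2 (1.27 log units; beyond the scatter), and among these three compounds the order runs cycloheptyl, cyclopentyl, phenyl, from the lowest number to the highest. No accompanying data bear on why the two saturated rings differ, so the ordering stands here as an observation only.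

The compounds shown leave open whether the read-out follows ring size steadily or passes through an optimum, a question that cyclohexyl and cyclooctyl on the same carbonyl carbon would address. Also open, from the compounds shown here alone, is whether a ring is needed at all, or whether an open chain such as n-hexyl, or a cycloheptyl ring carrying an amine, would hold the number of compound 2 at 20 nM.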